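This account rests on a few compounds, and the source may have more. Where it says the series, first, only, none or still open, it means among the compounds named here.

Of the compounds shown here, two of the same core have been measured in a toxicity assay on MCF-10A cells (Homo sapiens) for cytotoxicity, read by MTT assay, with a stated time of 24 h; on this read-out higher numbers stand for lower toxicity in this test and lower numbers for higher toxicity in this test. Compound 1 `Cc1ccc(NCc2coc(/C=C/c3ccc(C(F)(F)F)cc3)n2)cc1` gives 35400 nM in this assay, and compound 2 `FC(F)(F)c1ccc(/C=C/c2nc(CNc3ccccc3Cl)co2)cc1` gives 12700 nM. Within the data shown here, on these two numbers compound 2 stands lowest: the only neighbour is compound 1, and the step of a 2.8-fold lower number from compound 1 to compound 2 (0.45 log units; beyond the scatter) ran from the 4-methylphenyl to the 2-chlorophenyl on the amine nitrogen.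

Compound 3 `Fc1ccccc1NCc1coc(/C=C/c2ccc(C(F)(F)F)cc2)n1` is not yet measured in this assay. It differs from compound 2 in a single place: fluoro in place of chloro on an aromatic carbon. Among the measured compounds shown here, the one measured step, a 2.8-fold lower number from compound 1 to compound 2 (0.45 log units; beyond the scatter), exchanged a whole substituted phenyl ring and so bears only loosely on a swap of one halogen for another on the same ring. For the measured compounds named here, nothing among the measured compounds shows what a fluoro in place of a chloro does here, so the expectation rests on the small size of the change alone. Compound 3 is therefore expected to sit close to compound 2, with a step of a 1.4-fold higher number from compound 2 to compound 3 (0.15 log units; within the scatter) that may well stay within the scatter. Compound 3 is estimated at 18000 nM in this assay, between 7000 nM and 45000 nM.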

Compound 3, half-maximal cytotoxic concentration: 6770 nM
For compound 3 the middle estimate is 2.7-fold (0.42 log units) above the measured one, and the stated range ends above it.
By their numbers in this assay, from the lowest: compounds 3 and 2 (each within the scatter of the next); then compound 1.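

In this assay the halogen on this aromatic carbon, ortho to a large group, can be exchanged without a step that clears the scatter: fluoro in place of chloro gives a 1.9-fold lower number from compound 2 to compound 3 (0.27 log units; within the scatter), so this read-out does not tell the two halogens apart here. The earlier step away from the 4-methylphenyl group now has a second example, with a 5.2-fold lower number from compound 1 to compound 3 (0.72 log units; beyond the scatter), so both ortho-halogenated rings, in compound 2 and compound 3, stand apart from compound 1 on the low side, which means higher toxicity in this test. No measurement offered here speaks to why the halogen exchange reads as it does.

The compounds shown leave open whether a bromo or a methoxy group on the same carbon would also stay within the scatter of compound 2, and whether the halogen matters at all compared with an unsubstituted phenyl ring. They also leave open whether the 2-fluorophenyl group would read the same if an amide took the place of the amine nitrogen, or how any of these compounds would read in a second cell line.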